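A few compounds are considered here, and "the series" means these few. Any claim that something is new, unique, unknown or untested is made for them only; others in the source may bear on it.

Three compounds share one core and were tested in a functional assay on U-87MG ATCC cells for inhibition, with U-87 MG (Homo sapiens) as the target, read by MTT assay, with a stated time of 72 h; a higher number here means a weaker inhibitor, a lower number a stronger inhibitor. Compound 1 `Cc1noc(C)c1-c1cnc(N)c(Oc2ccc(C(=O)Nc3cccc(Cl)c3)cc2)n1` gives 11500 nM. Compound 2 `Cn1cc(-c2cnc(N)c(Oc3ccc(C(=O)Nc4ccccc4Cl)cc3)n2)cn1` gives 44800 nM, and compound 3 `Cn1cc(-c2cnc(N)c(Oc3ccc(C(=O)Nc4ccc(Cl)cc4)cc3)n2)cn1` gives 35800 nM. Among these three numbers compound 3 stands second highest: its nearest neighbour is compound 2, within the scatter, and its furthest is compound 1, whose number is lower by a margin beyond the scatter.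

Compound 4 `Cn1cc(-c2cnc(N)c(Oc3ccc(C(=O)Nc4cccc(Cl)c4)cc3)n2)cn1` has not yet been measured. It differs from compound 3 only in the group on the amide-type nitrogen: 3-chlorophenyl in place of 4-chlorophenyl on an amide-type nitrogen. For the measured compounds named here, one measured step bears on this kind of change, the move of the chlorine around the same ring in a 1.3-fold lower number from compound 2 to compound 3 (0.10 log units; within the scatter), which stayed within the scatter. Compound 1 also carries a 3-chlorophenyl group, but its other ring substituent differs, so its value only shows that this group is compatible with a lower number in this series.

On this basis the step from compound 3 to compound 4 is expected to be small, a 1.3-fold lower number from compound 3 to compound 4 (0.11 log units; within the scatter), with at most a mild lean toward a lower number. Compound 4 is therefore estimated at 28000 nM, with a range from 12000 nM to 60000 nM.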

Compound 4, half-maximal inhibitory concentration: 21700 nM
The estimate for compound 4 lay 1.3-fold (0.11 log units) above the measured number, and the stated range covers the measured number.
By their numbers in this assay, from the lowest: compounds 1, 4, 3 and 2 (each within the scatter of the next, the first and the last beyond it).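

In this assay, 3-chlorophenyl in place of 4-chlorophenyl on the amide-type nitrogen gives a 1.6-fold lower number from compound 3 to compound 4 (0.22 log units; within the scatter), so these two placements of the chlorine cannot be told apart, while 3-chlorophenyl in place of 2-chlorophenyl gives a 2.1-fold lower number from compound 2 to compound 4 (0.31 log units; beyond the scatter), a modest step and the first in this set to clear the scatter. For the compounds shown here, compound 4 also supplies the first pair with the chlorophenyl amide held constant: 1-methyl-1H-pyrazol-4-yl in place of 3,5-dimethyl-1,2-oxazol-4-yl on an aromatic carbon gives a 1.9-fold higher number from compound 1 to compound 4 (0.28 log units; within the scatter), so the two groups cannot be separated in this pair. No accompanying measurement offers an explanation for any of these steps.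

Every compound shown carries a single chlorine on the phenyl ring attached to the amide-type nitrogen, so it remains open how a methoxy group, an amine or a carboxylic acid would read in its place. As far as these compounds go, it is also open whether 2-chlorophenyl and 4-chlorophenyl would give similar steps alongside the 3,5-dimethyl-1,2-oxazol-4-yl group.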